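The source may report more compounds than this note shows. Statements on the series, on what has been measured and on what is new or still open speak of the compounds shown alone.

Compound 3 belongs to a small set of three measured compounds sharing one core. Compound 4, `COc1cc2c(cc1OC)C(CC(=O)NC1CCCC1)CC2`, is the compound whose number is still to come. In a functional assay on the whole organism (strain Swiss albino) for inhibition, with Mus musculus as the target, in the writhing test, with stated times of 60 min and 15 min, at a dose of 100 mg/kg by the oral route (a lower number here means less inhibition, a higher number more inhibition at the dose given (going by the name of the read-out)), compound 3, `CCCNC(=O)CC1CCc2cc(OC)c(OC)cc21`, gives 26.9%. Compound 1, `COc1cc2c(cc1OC)C(CC(=O)O)CC2`, gives 44%, and compound 2, `CCNC(=O)CC1CCc2cc(OC)c(OC)cc21`, gives 23.6%. Among these three numbers compound 3 stands second highest: its nearest neighbour is compound 2, the difference being a number 3.3 percentage points higher from compound 2 to compound 3 (within the scatter), while the larger gap is a number 17.1 percentage points lower from compound 1 to compound 3 (beyond the scatter), and for compound 2 it is a number 20.4 percentage points lower from compound 1 to compound 2 (beyond the scatter).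

The step from compound 3 to compound 4 is cyclopentyl in place of propyl on an amide-type nitrogen. Among the measured compounds shown here, of the measured steps, only the one from compound 2 to compound 3 touches the group on the amide-type nitrogen, and that step was a number 3.3 percentage points higher from compound 2 to compound 3 (within the scatter). The two larger steps both concern the change from acid to amide at the carbonyl carbon and so say nothing about what a bigger group on the nitrogen does. On this basis the step expected in this assay, a number 1.1 percentage points higher from compound 3 to compound 4 (within the scatter), is small and may well stay within the scatter, in no clear direction. Compound 4 is therefore estimated at 28%, with a range from 14% to 42%.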

Compound 4, a percentage reported as inhibition, in the whole organism at one dose (the size of the read-out at that dose, not a potency): 37%
For compound 4 the middle estimate is 9 percentage points below the measured one, and the stated range covers the measured number.
By their numbers in this assay, from the lowest: compounds 2 and 3 (each within the scatter of the next); then compounds 4 and 1 (each within the scatter of the next).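

In this assay the group on the amide-type nitrogen turns out to matter: ethyl and propyl could not be told apart, with a number 3.3 percentage points higher from compound 2 to compound 3 (within the scatter), yet cyclopentyl in place of propyl gives a number 10.1 percentage points higher from compound 3 to compound 4 (beyond the scatter) and cyclopentyl in place of ethyl gives a number 13.4 percentage points higher from compound 2 to compound 4 (beyond the scatter) as well. The earlier amides suggested that replacing the hydroxy on the carbonyl carbon lowers the number, but cyclopentylamino in that place gives a number 7 percentage points lower from compound 1 to compound 4 (within the scatter), so this amide cannot be told apart from the acid and the loss seen with ethylamino and propylamino does not hold for every amide. Nothing measured here explains this gain.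

Cyclopentyl differs from propyl both in its ring and in its added carbon atoms, so these compounds cannot say which of the two goes with the higher number; an open pentyl chain would separate them. Going by these compounds, how far the trend runs also stays open, since cyclopropyl, cyclohexyl or a phenyl ring on the same nitrogen would show whether other rings behave like cyclopentyl.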